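This account rests on a few compounds, and the source may have more. Where it says the series, first, only, none or still open, it means among the compounds named here.

Measured in a functional assay on PC-3 cells (Homo sapiens) for cytotoxicity; a lower number here means that less compound is needed, a higher number that more compound is needed for the effect:
Compound 1 `COC1=C(C)C(=O)/C(=C(O)/C=C/c2ccc(Br)cc2)C(=O)C1(C)C`: 17.7 ug/mL
Compound 2 `COC1=C(C)C(=O)/C(=C(O)/C=C/c2cccc(OC)c2)C(=O)C1(C)C`: 14.3 ug/mL
Compound 3 `COC1=C(C)C(=O)/C(=C(O)/C=C/c2ccc(C)cc2)C(=O)C1(C)C`: 8.2 ug/mL

Compound 3 stands clearly apart from only one of the other two. The data show a 2.2-fold lower number from compound 1 to compound 3 (0.33 log units; beyond the scatter), but also a 1.7-fold lower number from compound 2 to compound 3 (0.24 log units; within the scatter).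

Compound 4 `COC1=C(C)C(=O)/C(=C(O)/C=C/c2ccccc2C)C(=O)C1(C)C` carries 2-methylphenyl in place of 4-methylphenyl (2-methylphenyl in place of 4-methylphenyl on a double-bonded chain carbon bound to a double-bonded chain carbon). Among the measured compounds shown here, no measured pair makes this exact exchange, so the nearest guides are the other swaps at this place. Besides the two steps above, these include a 1.2-fold lower number from compound 1 to compound 2 (0.09 log units; within the scatter). All three are small, so no change beyond the scatter is expected in this assay. The expected step is a 1.3-fold higher number from compound 3 to compound 4 (0.11 log units; within the scatter). The estimate for compound 4 is 10.5 ug/mL, with a range from 5.5 ug/mL to 20 ug/mL.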

Compound 4, concentration for half-maximal effect: 9 ug/mL
For compound 4 the middle estimate is 1.2-fold (0.07 log units) above the measured one; measured number inside the range.
By their numbers in this assay, from the lowest: compounds 3, 4, 2 and 1 (each within the scatter of the next, the first and the last beyond it).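

Exchanging 4-methylphenyl for 2-methylphenyl gives no readable difference in this assay (a 1.1-fold higher number from compound 3 to compound 4 (0.04 log units; within the scatter)), so for this pair the place of the methyl on the aromatic ring does not register. The 2-methylphenyl group also stays within the scatter of the other two groups (a 1.6-fold lower number from compound 2 to compound 4 (0.20 log units; within the scatter); a 2.0-fold lower number from compound 1 to compound 4 (0.29 log units; within the scatter)), whereas 4-methylphenyl stood clear of 4-bromophenyl. Nothing measured here explains this match between the two methyl placements.

From the compounds shown here alone, whether 3-methylphenyl would fall with these two remains open. So does whether an amine or a carboxylic acid in place of the methyl would produce a step beyond the scatter.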